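The source may hold more compounds than are shown below. What is called first, only, known or untested is meant among the compounds shown, and "the series" means these compounds.

Working notes on the series. The core is shared throughout; compound 1 `COCC(C)Oc1cccc2ccc(N)nc12` carries a 1-(methoxymethyl)ethyl group on the ring oxygen and in an assay on cells with melanin-concentrating hormone receptor 1 (Homo sapiens) as the target, read by radioligand binding (on this read-out lower numbers stand for stronger inhibition and higher numbers for weaker inhibition), compound 1 gives 606 nM. Compound 2 `CC1CC1COc1cccc2ccc(N)nc12` gives 1640 nM in this assay. Compound 3 `Nc1ccc2cccc(OC3CCCC3)c2n1` reaches only a limit of this assay, > 2000 nM. This is the limit of > 2000 nM in this assay, at which 1 of the 3 values shown sits, so compound 3 stands as a floor, not a number. The measured step bearing on the next move is an at least 3.3-fold higher number from compound 1 to compound 3 (0.51 log units; beyond the scatter), the reverse of going from the ring onto an ether-bearing chain; an at least 1.2-fold higher number from compound 2 to compound 3 (0.08 log units; that floor lies within the scatter) adds little. Compound 4 `CC(C)OCCOc1cccc2ccc(N)nc12` carries 2-isopropoxyethyl in place of cyclopentyl on an oxygen on an aromatic ring. Since compound 4, like compound 1, holds an ether-bearing open chain rather than a ring of carbon only, compound 4 is expected to step back down by an at least 2.5-fold lower number from compound 3 to compound 4 (0.39 log units; beyond the scatter). Compound 4 is estimated at 800 nM, within 250 nM to 3000 nM.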

Compound 4, half-maximal inhibitory concentration: > 2000 nM
Compound 4 gave a limit, no number; the forecaster's own chance of this, stated with the estimate: 15%; at least 2.5-fold (0.39 log units) between middle value and limit.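

The ether oxygen of an open chain does not by itself hold the reading of compound 1 at this position: in this assay there is an at least 3.3-fold higher number from compound 1 to compound 4 (0.51 log units; beyond the scatter). The remaining floor says little: an at least 1.2-fold higher number from compound 2 to compound 4 (0.08 log units; that floor lies within the scatter). The step between compound 3 and compound 4 cannot be read, and each now stands only as a limit: the limit of > 2000 nM in this assay, at which 2 of the 4 values shown sit.

From the compounds shown here alone, how far compound 3 and compound 4 lie beyond that limit stays open. So does whether a 2-methoxyethyl chain, or an amine at the chain end, would return toward compound 1.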